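The source may report more compounds than this note shows. Statements on the series, on what has been measured and on what is new or still open speak of the compounds shown alone.

Of the compounds shown here, two have so far been measured in a functional assay on CCRF-CEM cells (Homo sapiens) for inhibition, read by cell counting, with a stated time of 3 days; on this read-out higher numbers stand for weaker inhibition and lower numbers for stronger inhibition. Compound 1 `Nc1cccc(-c2cn3nc(Cc4ccccc4)sc3n2)c1` gives 37000 nM, while compound 2 `C=C(Br)C(=O)Nc1cccc(-c2cn3nc(-c4ccc(Cl)cc4)sc3n2)c1` gives 3200 nM, the lower of the two numbers, with the gap to compound 1 lying beyond the scatter. Compound 3 `Nc1cccc(-c2cn3nc(-c4ccc(Cl)cc4)sc3n2)c1` is not yet measured; it differs from compound 2 by hydrogen in place of (1-bromoethenyl)carbonyl on a nitrogen on an aromatic ring. Going by the values given here, no measured pair shows this change alone. A step toward weaker inhibition, a 7.8-fold higher number from compound 2 to compound 3 (0.89 log units; beyond the scatter), is expected, because compound 1, which also carries an amino group at that place, gives 37000 nM. Compound 3 is therefore estimated at 25000 nM, between 8000 nM and 80000 nM.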

Compound 3, half-maximal inhibitory concentration: > 250000 nM
Compound 3 gave a limit, no number; the forecaster's own chance of this, stated with the estimate: 20%; middle value at least 10-fold (1.00 log units) from the limit.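

For compound 3 the read-out gives a limit, not a number: the limit of > 250000 nM in this assay, at which 1 of the 3 values shown sits. On the nitrogen, losing the (1-bromoethenyl)carbonyl gives an at least 78-fold higher number from compound 2 to compound 3 (1.89 log units; beyond the scatter), so in this pair the inhibition seen in this assay depends on that group. Going by these compounds alone, with the amino group free, 4-chlorophenyl in place of benzyl gives an at least 6.7-fold higher number from compound 1 to compound 3 (0.82 log units; beyond the scatter), the first reading of a change at that other place.

Going by these compounds, whether a plain acetyl group or a propenoyl group without bromine on that nitrogen would hold the inhibition remains open. Also open, on these data alone, is how benzyl would behave alongside the (1-bromoethenyl)carbonyl.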